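The source may report more compounds than this note shows. Statements on the series, on what has been measured and on what is new or still open speak of the compounds shown alone.

Measured compounds:
compound 1 `CC(C)(C)N(NC(=O)c1ccccc1F)C(=O)c1ccccc1Cl` — 51.3 nM
compound 2 `CC(C)(C)N(NC(=O)c1cccc(C#N)c1)C(=O)c1ccccc1Cl` — 955 nM
compound 3 `CC(C)(C)N(NC(=O)c1ccc(I)cc1)C(=O)c1ccccc1Cl` — 7.59 nM

In an assay on cells for agonist activity at ecdysone receptor (Bombyx mori), read by a luciferase reporter, with a stated time of 24 h (on this read-out higher numbers stand for an effect only at larger amounts of compound and lower numbers for an effect already at smaller amounts), compound 1 stands second highest of the three, with compound 3 nearest a 6.8-fold lower number from compound 1 to compound 3 (0.83 log units; beyond the scatter) and compound 2 furthest a 19-fold higher number from compound 1 to compound 2 (1.27 log units; beyond the scatter). Compound 4 `Cc1cccc(C(=O)NN(C(=O)c2ccccc2Cl)C(C)(C)C)c1C` differs from compound 1 in one place: 2,3-dimethylphenyl in place of 2-fluorophenyl on a carbonyl carbon. Within the data shown here, no measured step replaces a 2-fluorophenyl with a dimethyl-bearing ring; the two steps from compound 1 show that this position tolerates both a modest drop in the number a 6.8-fold lower number from compound 1 to compound 3 (0.83 log units; beyond the scatter) and a large rise a 19-fold higher number from compound 1 to compound 2 (1.27 log units; beyond the scatter), and the step of a 130-fold lower number from compound 2 to compound 3 (2.10 log units; beyond the scatter) shows how wide the range is. Among the measured compounds shown here, with no closer precedent, compound 4 is expected to stay near compound 1, a 1.3-fold lower number from compound 1 to compound 4 (0.11 log units; within the scatter). The value of compound 4 in this assay is estimated at 40 nM, within 8 nM to 200 nM.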

Compound 4, half-maximal effective concentration: 20 nM
Compound 4: middle estimate off by 2.0-fold (0.30 log units), on the high side; the measured number falls inside the stated range.
By their numbers in this assay, from the lowest: compound 3; then compound 4; then compound 1; then compound 2.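

In this assay, the dimethyl-bearing ring shows that this carbonyl carbon accepts a ring without fluorine, iodine or nitrile, and the number falls relative to the 2-fluorophenyl compound (a 2.6-fold lower number from compound 1 to compound 4 (0.41 log units; beyond the scatter)) and far more relative to the 3-cyanophenyl compound (a 48-fold lower number from compound 2 to compound 4 (1.68 log units; beyond the scatter)). The 4-iodophenyl group still gives the lowest number of the four (a 2.6-fold higher number from compound 3 to compound 4 (0.42 log units; beyond the scatter)). Nothing given here explains these steps. Open, on these data alone, is whether a single methyl, a methoxy group or a longer chain such as ethyl on this ring would keep the number this low.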